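Chloro for methyl on the arylpiperazine of compound 3

A few compounds are considered here, and "the series" means these few. Any claim that something is new, unique, unknown or untested is made for them only; others in the source may bear on it.

Working notes on a small set sharing one core. Compound 3 is `CCCc1nc(-c2ccccc2)c(CNCCN2CCN(c3ccc(C)cc3)CC2)o1`, compound 2 is `CCCc1nc(-c2ccccc2)c(CNCCN2CCN(c3ccccc3Cl)CC2)o1` and compound 1 is `CCCc1nc(-c2ccccc2)c(CNCCCN2CCN(c3cccc(OC)c3)CC2)o1`. In an assay on HEK293 cells for inhibition of Voltage-dependent T-type calcium channel subunit alpha-1G (Homo sapiens), read by fluorescence, tested at 10 uM (on this read-out lower numbers stand for less inhibition and higher numbers for more inhibition at the one concentration tested (going by the name of the read-out)), compound 2 gives 60.1%, compound 3 gives 48.1% and compound 1 gives 36.4%. Compound 3 thus stands second highest of the three numbers, below compound 2 and above compound 1, and both gaps lie beyond the scatter. Compound 4 is `CCCc1nc(-c2ccccc2)c(CNCCN2CCN(c3ccc(Cl)cc3)CC2)o1`; it differs from compound 3 by chloro in place of methyl on an aromatic carbon. Going by the values given here, the only measured step that trades a chlorine for a methyl on the phenyl is a number 12 percentage points lower from compound 2 to compound 3 (beyond the scatter), a modest drop, yet that step also shifts where on the phenyl the group sits, so it bears on the present change only loosely. Among the compounds with values here, no measured pair sets chloro against methyl at the same site. A small rise, if any, is expected for compound 4, of about a number 4.9 percentage points higher from compound 3 to compound 4 (within the scatter). Compound 4 is estimated at 53%, with a range from 36% to 68%.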

Compound 4, a percentage reported as inhibition, at one concentration (the size of the read-out at that concentration, not a potency): 55.8%
The estimate for compound 4 lay 2.8 percentage points below the measured number; measured number inside the range.
By their numbers in this assay, from the lowest: compound 1; then compounds 3, 4 and 2 (each within the scatter of the next, the first and the last beyond it).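

In this assay, going by these compounds alone, the change from 4-methylphenyl to 4-chlorophenyl gives the first comparison of chloro and methyl at one site, and a number 7.7 percentage points higher from compound 3 to compound 4 (within the scatter) leaves the two groups unresolved there. Keeping chloro and shifting it, 4-chlorophenyl in place of 2-chlorophenyl, gives a number 4.3 percentage points lower from compound 2 to compound 4 (within the scatter) and so leaves these two chloro placements unresolved as well, whereas the earlier step that changed both group and site, a number 12 percentage points lower from compound 2 to compound 3 (beyond the scatter), is the only one of the three beyond the scatter. Nothing at hand gives a cause for any of these steps.

As far as these compounds go, whether a trifluoromethyl or a nitrile on this phenyl would move the number beyond the scatter stays open. The part played by the linking chain also stays unread: compound 1 differs from the others in more than one place.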